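A few compounds are considered here, and "the series" means these few. Any claim that something is new, unique, unknown or untested is made for them only; others in the source may bear on it.

Measured so far:
- Compound 1 `O=C(Nc1cccc(CNc2nccnc2Cl)c1)Nc1ccccc1F`: 6440 nM
- Compound 2 `Cc1ccc(NC(=O)Nc2cccc(CNc3nccnc3Cl)c2)c(C)c1`: 10100 nM
- Compound 3 `O=C(Nc1cccc(CNc2nccnc2Cl)c1)Nc1ccc(Cl)c(Cl)c1`: 4970 nM

These three compounds share one core and differ only in the aromatic group attached to an amide-type nitrogen. In a functional assay on MGC-803 cells (Homo sapiens) for antiproliferative activity, read by MTT assay, with a stated time of 48 h (a lower number here means a stronger inhibitor, a higher number a weaker inhibitor), compound 3 gives 4970 nM, the lowest of the three numbers; the two steps that lead to it are a 1.3-fold lower number from compound 1 to compound 3 (0.11 log units; within the scatter) and a 2.0-fold lower number from compound 2 to compound 3 (0.31 log units; beyond the scatter). So compound 3 is only modestly set apart from compound 2 and not at all from compound 1.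

Compound 4 `COc1ccc(NC(=O)Nc2cccc(CNc3nccnc3Cl)c2)cc1` is the next member of this set, not yet measured. Its difference from compound 3 is 4-methoxyphenyl in place of 3,4-dichlorophenyl on an amide-type nitrogen.

The two measured steps that bear on this one are those that swap the same aromatic group on the same nitrogen: a 1.3-fold lower number from compound 1 to compound 3 (0.11 log units; within the scatter) and a 2.0-fold lower number from compound 2 to compound 3 (0.31 log units; beyond the scatter). Both are small, and all three aromatic groups tried so far land within a narrow band. For the measured compounds named here, nothing among the measured compounds singles out a methoxy-bearing ring, so the change from compound 3 to compound 4 is expected to give at most a modest step toward a higher number, of about a 1.4-fold higher number from compound 3 to compound 4 (0.15 log units; within the scatter).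

Compound 4 is therefore estimated at 7000 nM in this assay, with a likely range from 3500 nM to 14000 nM.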

Compound 4, half-maximal inhibitory concentration: 9240 nM
Beside the measured number, compound 4's estimate is 1.3-fold (0.12 log units) below it; low and high end bracket the measured number.
By their numbers in this assay, from the lowest: compounds 3, 1, 4 and 2 (each within the scatter of the next, the first and the last beyond it).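

In this assay, putting 4-methoxyphenyl in place of 3,4-dichlorophenyl on the amide-type nitrogen gives a 1.9-fold higher number from compound 3 to compound 4 (0.27 log units; within the scatter), so exchanging two chlorine atoms for one methoxy group, which brings a hydrogen-bond acceptor where the group it replaces has none, makes no difference that can be told from the scatter. The other two new steps, a 1.1-fold lower number from compound 2 to compound 4 (0.04 log units; within the scatter) and a 1.4-fold higher number from compound 1 to compound 4 (0.16 log units; within the scatter), are also within the scatter, so among the four compounds only compound 2 and compound 3 are separated beyond it, and this position has so far accepted four differently substituted phenyl rings with little effect on the number. Nothing shown explains why these rings give such similar numbers.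

From the compounds shown here alone, all four compounds keep a phenyl ring on this nitrogen, so it remains open whether a saturated ring such as cyclohexyl, a longer alkyl chain, or a phenyl ring carrying an amine or a carboxylic acid would move the number well outside this narrow band. The rest of the shared core is the same in all four, so these compounds also cannot show how changes elsewhere in the molecule would affect the number.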